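The source may report more compounds than this note shows. Statements on the series, on what has been measured and on what is new or still open speak of the compounds shown alone.

Three compounds have been measured so far:

compound 1 `Cc1nn(C)c2c1C(c1cccc(Cl)c1)=NCCN2`: 0.63 mg/kg
compound 2 `Cc1nn(C)c2c1C(c1cccc(Cl)c1)=NCCN2N=O`: 1.25 mg/kg
compound 3 `Cc1nn(C)c2c1C(c1cccc(Cl)c1)=NCCN2CCN1CCCC1`: > 10 mg/kg, which is a limit of the assay and not a number

In a functional assay on the whole organism for positive allosteric modulation, with Rattus norvegicus as the target (on this read-out higher numbers stand for an effect only at larger amounts of compound and lower numbers for an effect already at smaller amounts), compound 1 has the lowest of the two numbers. The step of a 2.0-fold higher number from compound 1 to compound 2 (0.30 log units; within the scatter) is within the scatter, so compound 1 and compound 2 cannot be told apart on these data. For compound 3 only the limit of > 10 mg/kg in this assay, at which 1 of the 3 values shown sits, is known. The step of an at least 15-fold higher number from compound 1 to compound 3 (1.20 log units; beyond the scatter) and the step of an at least 8.0-fold higher number from compound 2 to compound 3 (0.90 log units; beyond the scatter) both lie beyond the scatter; all three measured steps change the substituent on a nitrogen on an aromatic ring in a ring.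

Compound 4 `Cc1n[nH]c2c1C(c1cccc(Cl)c1)=NCCN2` differs from compound 1 by hydrogen in place of methyl on an aromatic nitrogen. Going by the values given here, none of the measured steps touches this aromatic nitrogen, so none of them bears directly on the change, and no step beyond the scatter is expected in this assay . Compound 4 is therefore estimated to give 0.63 mg/kg, with a range from 0.25 mg/kg to 1.6 mg/kg. The expected step is no change at the digits printed from compound 1 to compound 4 (within the scatter).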

Compound 4, minimum effective dose: 2.5 mg/kg
Beside the measured number, compound 4's estimate is 4.0-fold (0.60 log units) below it; measured number above the stated range.
By their numbers in this assay, from the lowest: compounds 1, 2 and 4 (each within the scatter of the next, the first and the last beyond it). At a limit, above all of these: compound 3.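

The methyl group on the aromatic nitrogen of the five-membered aromatic ring matters in this assay: a 4.0-fold higher number from compound 1 to compound 4 (0.60 log units; beyond the scatter). Going by these compounds alone, the earlier steps all changed the substituent on a different nitrogen, so this is the first sign that replacing this methyl with hydrogen has an effect beyond the scatter, with compound 4 needing a larger amount of compound than compound 1 to show an effect. Nothing shown here gives a reason for this step.

From the compounds shown here alone, what ethyl, a longer chain or a carboxylic acid on this aromatic nitrogen would do remains open. Going by these compounds, it also remains open whether removing the methyl group would have the same effect when the other nitrogen carries a substituent, as it does in compound 2.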